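The source may report more compounds than this note shows. Statements on the series, on what has been measured and on what is new or still open speak of the compounds shown alone.

Measured so far:
Compound 1 `O=C(O)Cn1c(SCCNc2ccccc2)nc2ccccc21`: in an assay on HEK293 cells for displacement of a labelled ligand from prostaglandin D2 receptor 2 (Homo sapiens) (a lower number here means a stronger inhibitor, a higher number a weaker inhibitor), compound 1 gives 7690 nM.
Compound 2 `CCCCCCSc1nc2ccccc2n1CC(=O)O`: in this assay compound 2 gives 1360 nM.

Compound 2 stands at the lower of the two numbers; its nearest neighbour is compound 1, and the gap between them, a 5.7-fold lower number from compound 1 to compound 2 (0.75 log units; beyond the scatter), lies beyond the scatter. That step exchanged the anilino group at the end of the thioether chain for a plain alkyl group.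

Compound 3 `CCOC(=O)CCCSc1nc2ccccc2n1CC(=O)O` has not yet been tested. It differs from compound 2 in one place: ethoxycarbonyl in place of propyl on a saturated chain carbon, three bonds along the chain from a sulfur. The chain keeps its length from the sulfur, but its end now carries the ester with its two acceptors instead of a plain alkyl tail.

Among the measured compounds shown here, only one measured step bears on this, a 5.7-fold lower number from compound 1 to compound 2 (0.75 log units; beyond the scatter), where removing a hydrogen-bonding group from the chain end and leaving alkyl gave the lower number. Putting an oxygen-bearing group back at the chain end is expected to move in the opposite direction, though the ester is not an anilino group and a smaller shift than a 5.7-fold lower number from compound 1 to compound 2 (0.75 log units; beyond the scatter) is expected. For compound 3 the expected step is a 2.4-fold higher number from compound 2 to compound 3 (0.37 log units; beyond the scatter), and compound 3 is estimated at 3200 nM in this assay, within 1100 nM to 9500 nM.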

Compound 3, half-maximal inhibitory concentration: 4410 nM
Compound 3: middle estimate off by 1.4-fold (0.14 log units), on the low side, within the range that was stated.
By their numbers in this assay, from the lowest: compound 2; then compounds 3 and 1 (each within the scatter of the next).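

The change from propyl to ethoxycarbonyl gives a 3.2-fold higher number from compound 2 to compound 3 (0.51 log units; beyond the scatter) in this assay and so shows that the number at this chain end can rise without an anilino group. Set against that anilino group, the (ethoxycarbonyl)methyl end gives a 1.7-fold lower number from compound 1 to compound 3 (0.24 log units; within the scatter) in the same assay, a step within the scatter, so these two quite different ends cannot be told apart, and among the three compounds only the plain alkyl end of compound 2 stands apart. Nothing at hand explains why the ester end and the alkyl end differ at this position.

From the compounds shown here alone, it remains open whether the rise belongs to the ester itself or would follow any oxygen-bearing end, a question that a carboxylic acid, an ether or an alcohol at the same place on the chain could address. Equally open, going by these compounds, is how far the lower number of compound 2 depends on the length of its chain, which a shorter or a longer alkyl chain on the same sulfur would test.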